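Dihydropyridine aryl exchange: from iodophenyl to dichlorophenyl

This account rests on a few compounds, and the source may have more. Where it says the series, first, only, none or still open, it means among the compounds named here.

Measured compounds:
compound 1 `C=Cc1ccccc1C1C(C(=O)OC)=C(C)N=C(C)/C1=C(\O)OC`, 4.47 nM
compound 2 `COC(=O)C1=C(C)N=C(C)/C(=C(\O)OC)C1c1ccc(I)cc1`, 22900 nM
compound 3 `COC(=O)C1=C(C)N=C(C)/C(=C(\O)OC)C1c1cccc(OC(=O)c2ccccc2)c1`, 6310 nM

In a functional assay (muscle tissue) with Cavia porcellus as the target (on this read-out higher numbers stand for an effect only at larger amounts of compound and lower numbers for an effect already at smaller amounts), compound 2 has the highest number of the three, with compound 3 nearest and compound 1 furthest away. The unmeasured compound 4 `COC(=O)C1=C(C)N=C(C)/C(=C(\O)OC)C1c1cccc(Cl)c1Cl` differs from compound 2 by 2,3-dichlorophenyl in place of 4-iodophenyl on a saturated ring carbon. Among the measured compounds shown here, only one measured step touches this position: a 5100-fold higher number from compound 1 to compound 2 (3.71 log units; beyond the scatter), showing that the aryl group on that saturated carbon can move this read-out by a very large amount. For the measured compounds named here, a step back down is therefore expected for compound 4, whose number is expected to fall by a 1900-fold lower number from compound 2 to compound 4 (3.28 log units; beyond the scatter), though no measured step fixes its size precisely. Compound 4 is estimated at 12 nM, within 1.5 nM to 100 nM.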

Compound 4, half-maximal effective concentration: 19.1 nM
For compound 4 the middle estimate is 1.6-fold (0.20 log units) below the measured one; the range from low to high includes it.
By their numbers in this assay, from the lowest: compound 1; then compound 4; then compound 3; then compound 2.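

In this assay the exchange gives a 1200-fold lower number from compound 2 to compound 4 (3.08 log units; beyond the scatter) and so shows that a low number at this position does not depend on 2-vinylphenyl, since 2,3-dichlorophenyl also brings it far down. The two groups are still not interchangeable, as a 4.3-fold higher number from compound 1 to compound 4 (0.63 log units; beyond the scatter) is a modest step but lies beyond the scatter. Nothing measured here accounts for the size of either step.

The compounds shown leave open whether a single chlorine would be enough on this aryl ring. They also leave open how a nitro group or an amine would fare there.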